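Pyrimidin-2-yl in place of 1,3-oxazol-2-yl in compound 2

The compounds below may be only part of what the source reports. "The series", "measured", "known", "first", "only" and "open" are said of these compounds alone.

Within the data shown here, in a physicochemical assay for lipophilicity, read by HPLC, at pH 7.4 (a lower number here means a more polar compound, a higher number a more lipophilic compound), compound 1 `COc1cc2oc(=O)n(CCC(=O)O)c2cc1Cl` was reported as "not determined" (no result reported), so compound 2 `C[C@@H](Oc1cc2oc(=O)n(CCC(=O)O)c2cc1Cl)c1ncco1`, at 1.11, holds the only number available. Compound 3 `C[C@@H](Oc1cc2oc(=O)n(CCC(=O)O)c2cc1Cl)c1ncccn1` carries pyrimidin-2-yl in place of 1,3-oxazol-2-yl on a saturated chain carbon bound to an oxygen on an aromatic ring and a saturated chain carbon. Among the measured compounds shown here, no measured pair offers a guide here, so no change beyond the scatter is expected, with only a slight lean towards a lower number. The estimated change is a number 0.11 log units lower from compound 2 to compound 3 (within the scatter). For compound 3 the expected value is 1, within an estimated range of 0.6 to 1.4.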

Compound 3, distribution coefficient: 0.83
For compound 3 the middle estimate is 0.17 log units above the measured one, within the range that was stated.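

In this assay, pyrimidin-2-yl in place of 1,3-oxazol-2-yl on a saturated chain carbon bound to an oxygen on an aromatic ring and a saturated chain carbon gives a number 0.28 log units lower from compound 2 to compound 3 (within the scatter). Among these compounds, this is the first step that can be read at this position, and it shows that a six-membered aromatic ring with 2 hetero atoms and a five-membered one cannot be told apart here. No evidence on the cause of this result is at hand. On these data alone, whether a phenyl ring or an amine on the same carbon would give a step beyond the scatter stays open.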